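A few compounds are considered here, and "the series" means these few. Any claim that something is new, unique, unknown or untested is made for them only; others in the source may bear on it.

Compound 3, drawn as `Cc1ccccc1-c1ncnc2c1C(=O)N(Cc1cc(C(F)(F)F)cc(C(F)(F)F)c1)CCCO2`, carries no substituent on the carbon that sits between the two ring nitrogens of its shared core. In a functional assay on ileum for antagonist activity at Substance-P receptor (Cavia porcellus) (a higher number here means a weaker inhibitor, a lower number a stronger inhibitor), compound 3 gives 11.6 nM, the second highest of the three numbers recorded: compound 1, drawn as `Cc1ccccc1-c1nc(N(C)C)nc2c1C(=O)N(Cc1cc(C(F)(F)F)cc(C(F)(F)F)c1)C[C@@H](C)CO2`, gives 52.9 nM, and compound 2, drawn as `Cc1ccccc1-c1nc(N(C)C)nc2c1C(=O)N(Cc1cc(C(F)(F)F)cc(C(F)(F)F)c1)C[C@H](C)CO2`, gives 0.427 nM. Among the compounds with values here, those two compounds carry a dimethylamino group and an extra methyl on the saturated ring, and the only measured step between them is a 120-fold lower number from compound 1 to compound 2 (2.09 log units; beyond the scatter), a change that rests on the fact that compounds 1 and 2 differ only in the configuration as drawn alone.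

Compound 4, drawn as `Cc1ccccc1-c1nc(N(C)C)nc2c1C(=O)N(Cc1cc(C(F)(F)F)cc(C(F)(F)F)c1)CCCO2`, is compound 3 with one change: dimethylamino in place of hydrogen on an aromatic carbon. Within the data shown here, no measured step covers this exact change, since compounds 1 and 2 also differ from compound 3 by the methyl on the saturated ring; their values merely show that a dimethylamino-bearing core can give numbers on either side of compound 3. On that basis compound 4 is expected to move by a 3.9-fold lower number from compound 3 to compound 4 (0.59 log units; beyond the scatter) in this assay, a modest step towards a lower number, with wide uncertainty. The estimate for compound 4 is 3 nM, within a range from 0.4 nM to 20 nM.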

Compound 4, antagonist equilibrium constant: 0.679 nM
Beside the measured number, compound 4's estimate is 4.4-fold (0.65 log units) above it; the range from low to high includes it.
By their numbers in this assay, from the lowest: compounds 2 and 4 (each within the scatter of the next); then compound 3; then compound 1.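

With no methyl on the saturated ring to confuse the reading, dimethylamino in place of hydrogen on the aromatic carbon between two ring nitrogen atoms gives a 17-fold lower number from compound 3 to compound 4 (1.23 log units; beyond the scatter) in this assay, so this one group at this position accounts for a large gain in potency. Taking the methyl off the saturated ring then gives a 1.6-fold higher number from compound 2 to compound 4 (0.20 log units; within the scatter), so the low number of compound 2 does not depend on that methyl. The same removal gives a 78-fold lower number from compound 1 to compound 4 (1.89 log units; beyond the scatter), which shows that the methyl is not neutral in every drawing and that its outcome turns on configuration, the single point separating the two methyl-bearing compounds: the fact that compounds 1 and 2 differ only in the configuration as drawn.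

The compounds shown hold only hydrogen or dimethylamino at the aromatic position, so it remains open whether a smaller amine such as methylamino, a cyclic amine such as pyrrolidine, or a methoxy group would give a similar step. From the compounds shown here alone, it is also open how an ethyl group on the same saturated ring carbon would behave in either configuration.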